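The source may report more compounds than this note shows. Statements on the series, on what has been measured and on what is new or still open speak of the compounds shown alone.

Measured compounds:
Compound 1, `Cc1cc(N2CCC(N)CC2)c(S(C)(=O)=O)cc1C(=O)N=C(N)N`: 9.8 nM
Compound 2, `Cc1cc(-n2ccnc2)c(S(C)(=O)=O)cc1C(=O)N=C(N)N`: 23 nM

In a functional assay for inhibition of sodium/hydrogen exchanger (Oryctolagus cuniculus) (on this read-out lower numbers stand for stronger inhibition and higher numbers for weaker inhibition), compound 1 gives 9.8 nM, while compound 2 gives 23 nM. Among the compounds with values here, compound 2 thus holds the higher of the two numbers; its only neighbour is compound 1, and the step between them is a 2.3-fold higher number from compound 1 to compound 2 (0.37 log units; beyond the scatter), a modest shift beyond the scatter.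

Compound 3, `Cc1cn(-c2cc(C)c(C(=O)N=C(N)N)cc2S(C)(=O)=O)cn1`, differs from compound 2 by methyl in place of hydrogen on an aromatic carbon. Within the data shown here, the single measured step, from compound 1 to compound 2, exchanges one ring for another on an aromatic carbon and says nothing about a methyl placed on the five-membered ring, so no measured pair bears directly on this change. With no guidance in either direction, compound 3 is expected to show no change at the digits printed from compound 2 to compound 3 (within the scatter), that is, no step beyond the scatter. Compound 3 is accordingly estimated at 23 nM, within a range from 8 nM to 70 nM.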

Compound 3, half-maximal inhibitory concentration: 28 nM
The estimate for compound 3 lay 1.2-fold (0.09 log units) below the measured number; the range from low to high includes it.
By their numbers in this assay, from the lowest: compound 1; then compounds 2 and 3 (each within the scatter of the next).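

In this assay, methyl in place of hydrogen on an aromatic carbon of the five-membered aromatic ring, two ring bonds from the ring atom that bears a large group, gives a 1.2-fold higher number from compound 2 to compound 3 (0.09 log units; within the scatter), so at this position the added methyl brings no step beyond the scatter. Exchanging 4-aminopiperidin-1-yl for 4-methyl-1H-imidazol-1-yl gives a 2.9-fold higher number from compound 1 to compound 3 (0.46 log units; beyond the scatter), a modest step in the same direction as the one to the unsubstituted 1H-imidazol-1-yl. Nothing available explains either step.

The compounds shown leave open whether an aminomethyl group or a carboxylic acid on this same aromatic carbon would also stay within the scatter. They also leave open how a piperidin-1-yl ring without the amine would compare with 4-aminopiperidin-1-yl.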